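Sulfonyl aryl exchange and liver clearance in one series

This account rests on a few compounds, and the source may have more. Where it says the series, first, only, none or still open, it means among the compounds named here.

Measured so far:
compound 1 `O=S(=O)(c1cc(F)cc(F)c1)c1cnc2cc(F)ccc2c1-c1ccc(Cl)cc1` gives 0.03 mL/min in an ADME assay on microsomes from liver (Homo sapiens) for metabolic stability, tested at 2.5 uM; on this read-out lower numbers stand for slow clearance and higher numbers for fast clearance
compound 2 `O=S(=O)(c1cc(Cl)cc(Cl)c1)c1cnc2cc(F)ccc2c1-c1ccc(Cl)cc1` gives 0.13 mL/min in this assay

Within the data shown here, compound 2 stands highest of the two numbers; its nearest neighbour is compound 1, and the only measured step, a 4.3-fold higher number from compound 1 to compound 2 (0.64 log units; beyond the scatter), separates them. Among the measured compounds shown here, that step is the sole guide to how the group on the sulfonyl sulfur moves the read-out, and it shows that a change there can shift the number beyond the scatter.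

Compound 3 `COc1ccc(S(=O)(=O)c2cnc3cc(F)ccc3c2-c2ccc(Cl)cc2)cc1` has not yet been measured. It differs from compound 2 by 4-methoxyphenyl in place of 3,5-dichlorophenyl on a sulfonyl sulfur. For the measured compounds named here, no measured step covers a 4-methoxyphenyl at this place, so there is no direct precedent; the step from compound 1 to compound 2 tells only that swapping the sulfonyl aryl group has moved the number by a modest amount in one direction. With the group on compound 3 lying outside what has been tested, a step of modest size in either direction remains possible, and a value nearer to that of compound 1 is taken as the central case.

Compound 3 is therefore expected to give 0.06 mL/min in this assay, within 0.02 mL/min to 0.2 mL/min. This estimate implies a 2.2-fold lower number from compound 2 to compound 3 (0.34 log units; beyond the scatter), which is expected rather than known.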

Compound 3, intrinsic clearance in a liver preparation (reported as CLH), per the amount of preparation that the assay uses: 1.28 mL/min
Compound 3: the middle estimate sits 21-fold (1.33 log units) below what was measured; measured number above the stated range.
By their numbers in this assay, from the lowest: compound 1; then compound 2; then compound 3.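

In this assay, the group on the sulfonyl sulfur proves far more sensitive than the exchange of one halogen for another could show: 4-methoxyphenyl in place of 3,5-dichlorophenyl gives a 9.8-fold higher number from compound 2 to compound 3 (0.99 log units; beyond the scatter), and 4-methoxyphenyl in place of 3,5-difluorophenyl gives a 43-fold higher number from compound 1 to compound 3 (1.63 log units; beyond the scatter). Both steps point the same way and lie beyond the scatter, so among these three compounds the 4-methoxyphenyl group stands at the fast-clearance end, with the two dihalophenyl groups at the slow-clearance end. The 3,5-dichlorophenyl and 4-methoxyphenyl groups have the same 8 heavy atoms, so heavy-atom count does not separate compound 2 from compound 3, although the entering group brings 1 hydrogen-bond acceptor.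

No measurement at hand bears on why the number rises with this exchange. The compounds shown leave open whether the rise follows from gaining the methoxy group or from losing both halogens, and how an unsubstituted phenyl, or a phenyl carrying an amine or a carboxylic acid, would read on the sulfonyl sulfur.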